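The compounds below may be only part of what the source reports. "The series", "measured", "known", "first", "only" and "open" are said of these compounds alone.

Measured so far:
- compound 1 `COc1ccc2c(c1)cc(CNCc1ccccc1)n2C`: in an assay on isolated protein for inhibition of Amine oxidase [flavin-containing] A (Homo sapiens), read by fluorescence, with stated times of 30 min and 1 h (a higher number here means a weaker inhibitor, a lower number a stronger inhibitor), compound 1 gives > 100000 nM; 100000 nM (2 entries).
- compound 2 `CCOC(=O)c1cc2cc(OCCCC3CCN(Cc4ccccc4)CC3)ccc2n1C`: in this assay compound 2 gives 1530 nM.

Among the measured compounds shown here, compound 2 carries the only numeric value in this assay; compound 1 contributes entries that do not settle on a single number (the several entries of compound 1 in this assay, > 100000 nM; 100000 nM (2 entries)), so no step between measured compounds can be drawn, and the shared core of compound 2 has no comparison beyond this single number.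

Compound 3 `Cn1c(C(=O)Nc2ccccc2)cc2cc(OCCCC3CCN(Cc4ccccc4)CC3)ccc21` has not been measured. The change from compound 2 is anilino in place of ethoxy on a carbonyl carbon, in words anilino in place of ethoxy on a carbonyl carbon. For the measured compounds named here, no measured step bears on this change. The expectation is a step no larger than the scatter, if anything toward slightly stronger inhibition, with the estimated step from compound 2 to compound 3 being a 1.5-fold lower number from compound 2 to compound 3 (0.18 log units; within the scatter). Compound 3 is therefore estimated at 1000 nM, within 200 nM to 5000 nM.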

Compound 3, half-maximal inhibitory concentration: > 100000 nM
Compound 3: only a limit was reported; the forecaster's own chance of this, stated with the estimate: 5%; middle value at least 100-fold (2.00 log units) away from the limit.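

In this assay, the place on a carbonyl carbon whose other neighbour is aromatic carbon proves sensitive to change: anilino in place of ethoxy gives an at least 65-fold higher number from compound 2 to compound 3 (1.81 log units; beyond the scatter). Among the compounds shown here, this is the first step that can be read, and it ties the number of compound 2 to the ethoxycarbonyl group, at least when set against phenylcarbamoyl. The result for compound 3 is a limit of the assay and not a number, so the step has a floor but no measured size: the limit of > 100000 nM in this assay, at which 1 of the 3 values shown sits.

The compounds shown do not separate the aromatic ring of the anilino group from the amide link itself as the source of the step. A methylamide or a carboxylic acid in this place would help to tell these two apart.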